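The source may report more compounds than this note shows. Statements on the series, on what has been measured and on what is new or still open speak of the compounds shown alone.

Compound 2 `CCN(CC)c1nc(C)nc2c(-c3c(C)cc(OC)cc3OC)c(C)nn12` and compound 1 `CCN(CC)c1nc(C)nc2c(-c3ccc(OC)c(C)c3C)c(C)nn12` share one core and differ in the substituted aromatic ring it carries. In an assay on cell membranes for displacement of a labelled ligand from corticotropin-releasing factor receptor 1 (Rattus norvegicus) (on this read-out lower numbers stand for stronger inhibition and higher numbers for weaker inhibition), compound 1 gives 38.6 nM, whereas compound 2 gives 1.2 nM, the lower of the two numbers and well beyond the scatter. Compound 3 `CCCN(c1nc(C)nc2c(-c3c(C)cc(OC)cc3OC)c(C)nn12)C1CC1` keeps the aromatic ring of compound 2 and carries cyclopropyl(propyl)amino in place of diethylamino on an aromatic carbon. Among the measured compounds shown here, no measured pair shows this exchange, so the expected step from compound 2 to compound 3 is estimated at a 1.2-fold lower number from compound 2 to compound 3 (0.08 log units; within the scatter), within the scatter in either direction. For compound 3 in this assay the estimate is 1 nM, with a range from 0.3 nM to 4 nM.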

Compound 3, half-maximal inhibitory concentration: 1.48 nM
Compound 3: middle estimate off by 1.5-fold (0.17 log units), on the low side; low and high end bracket the measured number.
By their numbers in this assay, from the lowest: compounds 2 and 3 (each within the scatter of the next); then compound 1.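

In this assay the exchange of diethylamino for cyclopropyl(propyl)amino, on the aromatic carbon between two ring nitrogen atoms, gives a 1.2-fold higher number from compound 2 to compound 3 (0.09 log units; within the scatter) and so leaves the two compounds level. Among the compounds shown here, compound 1 and compound 2 differ only in the aromatic ring, so this pair gives the first reading at this position, where an amine with a three-membered ring is accepted alongside the aromatic ring of compound 2. Nothing measured here explains this result. From the compounds shown here alone, whether morpholino or a longer chain such as dibutylamino would be accepted here remains open, as does whether cyclopropyl(propyl)amino would behave the same way with the aromatic ring of compound 1.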